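Trifluoromethyl for Methyl on the Aryl Ketone

The source may report more compounds than this note shows. Statements on the series, on what has been measured and on what is new or still open speak of the compounds shown alone.

Of the compounds shown here, three sharing one core have been tested in a functional assay on A549 cells (Homo sapiens) for cytotoxicity, read by MTT assay, with a stated time of 48 h; a higher number here means a weaker inhibitor, a lower number a stronger inhibitor. Compound 1 `COc1cc(C(=O)C2Sc3nnc(-c4cc(OC)c(OC)c(OC)c4)n3NC2c2ccco2)cc(OC)c1OC` gives 48300 nM. Compound 2 `COc1cc(-c2nnc3n2NC(c2ccco2)C(C(=O)c2ccc(Br)cc2)S3)cc(OC)c1OC` gives 42100 nM, and the change is a 1.1-fold lower number from compound 1 to compound 2 (0.06 log units; within the scatter). Compound 3 `COc1cc(-c2nnc3n2NC(c2ccco2)C(C(=O)c2ccc(C)cc2)S3)cc(OC)c1OC` reaches only the limit of this assay, > 100000 nM, which is a limit and not a number. The steps leading to it were an at least 2.0-fold higher number from compound 1 to compound 3 (0.31 log units; beyond the scatter) and an at least 2.3-fold higher number from compound 2 to compound 3 (0.37 log units; beyond the scatter), so compound 3 stands at the limit of > 100000 nM in this assay, at which 1 of the 3 values shown sits, weaker than both other compounds as far as the numbers show.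

Compound 4 `COc1cc(-c2nnc3n2NC(c2ccco2)C(C(=O)c2ccc(C(F)(F)F)cc2)S3)cc(OC)c1OC` differs from compound 3 by trifluoromethyl in place of methyl on an aromatic carbon. Among the measured compounds shown here, no measured step changes the group on this aromatic carbon in the same way; the nearest comparison, from bromo to methyl, was an at least 2.3-fold higher number from compound 2 to compound 3 (0.37 log units; beyond the scatter). A trifluoromethyl group is unlike either, so the direction of any step is uncertain and compound 4 is expected to stay near the limit. The expected step from compound 3 is a number no higher from compound 3 to compound 4 (the limit leaves the size open). Compound 4 is estimated at 100000 nM, within a range of 40000 nM to 250000 nM in this assay.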

Compound 4, half-maximal inhibitory concentration: 37200 nM
Compound 4: the middle estimate sits 2.7-fold (0.43 log units) above what was measured, outside the stated range (below it).
By their numbers in this assay, from the lowest: compounds 4, 2 and 1 (each within the scatter of the next). At a limit, above all of these: compound 3.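

In this assay, the methyl group on the aryl ketone proves to be the exception among the compounds shown, as trifluoromethyl at the same place gives a measurable value, an at least 2.6-fold lower number from compound 3 to compound 4 (0.42 log units; beyond the scatter). Trifluoromethyl does not set itself apart from the other two groups on the ketone, with a 1.1-fold lower number from compound 2 to compound 4 (0.05 log units; within the scatter) and a 1.3-fold lower number from compound 1 to compound 4 (0.11 log units; within the scatter), so 4-(trifluoromethyl)phenyl, 4-bromophenyl and 3,4,5-trimethoxyphenyl all give values within the scatter of one another. Compound 3 alone remains at a limit, which is not a number: the limit of > 100000 nM in this assay, at which 1 of the 4 values shown sits.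

The data do not tell why methyl alone stands apart from these three groups. Going by these compounds, whether a chloro group, a nitrile, an amine or a carboxylic acid at this place would follow methyl or the other three remains open.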